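This account rests on a few compounds, and the source may have more. Where it says the series, first, only, none or still open, it means among the compounds named here.

In a functional assay on MDA-MB-231 cells (Homo sapiens) for cytotoxicity, read by MTT assay, with a stated time of 48 h (on this read-out higher numbers stand for weaker inhibition and lower numbers for stronger inhibition), compound 1 (`O=C(NCCCCC(c1ccc(F)cc1)c1ccc(F)cc1)Nc1cccc(Cl)c1`) gives 5070 nM and compound 2 (`O=C(NCCCCC(c1ccc(F)cc1)c1ccc(F)cc1)Nc1ccc(Cl)c(C(F)(F)F)c1`) gives 3150 nM. Within the data shown here, these are the only two measured numbers so far, and they lie within the usual scatter of each other, so neither compound can be ranked above the other. Compound 3 (`O=C(NCCCCC(c1ccc(F)cc1)c1ccc(F)cc1)Nc1ccc(Cl)cc1C(F)(F)F`) keeps the core of compound 2 and changes only how the ring group is substituted: 4-chloro-2-(trifluoromethyl)phenyl in place of 4-chloro-3-(trifluoromethyl)phenyl on an amide-type nitrogen. In words, 4-chloro-2-(trifluoromethyl)phenyl stands in place of 4-chloro-3-(trifluoromethyl)phenyl on an amide-type nitrogen, with the same atoms joined differently. Among the measured compounds shown here, one measured step bears on this, since it altered the same group: a 1.6-fold lower number from compound 1 to compound 2 (0.21 log units; within the scatter). For the measured compounds named here, that step stayed within the scatter, though it is a different change, and no measured compound yet carries the new group. The evidence is therefore thin, and no shift beyond the scatter is expected. The expected step is a 1.1-fold higher number from compound 2 to compound 3 (0.05 log units; within the scatter). In this assay, compound 3 is estimated at 3500 nM, with an expected range from 1500 nM to 8000 nM.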

Compound 3, half-maximal inhibitory concentration: > 20000 nM
Compound 3: no number, only a limit; the forecaster's own chance of this, stated with the estimate: 3%; middle value at least 5.7-fold (0.75 log units) from the limit.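

In this assay, replacing 4-chloro-3-(trifluoromethyl)phenyl with 4-chloro-2-(trifluoromethyl)phenyl on the amide-type nitrogen, with the same atoms joined differently, gives an at least 6.3-fold higher number from compound 2 to compound 3 (0.80 log units; beyond the scatter), so the way this ring is substituted matters here, and not only which atoms it carries. The earlier change between ring groups stayed within the scatter, whereas the new group also stands apart from the 3-chlorophenyl group, with an at least 3.9-fold higher number from compound 1 to compound 3 (0.59 log units; beyond the scatter). The result for compound 3 is a limit of the assay and not a number, so the full size of both steps remains unknown: the limit of > 20000 nM in this assay, at which 1 of the 3 values shown sits.

Only compound 3 shows this weaker inhibition, so the compounds shown cannot tell whether the loss belongs to the trifluoromethyl group itself or would follow any group attached as it is in compound 3. From the compounds shown here alone, a methyl or a nitrile in place of that trifluoromethyl would help separate these two readings, and it also remains open whether a longer chain in the shared core would change the size of the step.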